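A few compounds are considered here, and "the series" means these few. Any claim that something is new, unique, unknown or untested is made for them only; others in the source may bear on it.

Measured so far:
compound 1, `O=C1Nc2ccccc2/C1=[N+](\[O-])Cc1ccccc1`: 1800 nM in a functional assay, read by spectrophotometry, with a stated time of 10 min; a higher number here means that more compound is needed for the effect, a lower number that less compound is needed
compound 2, `C/[N+]([O-])=C1\CCc2ccccc21`: 1300 nM in this assay

Among the compounds with values here, only two numbers are in hand, and they sit close together. Compound 2 stands at 1300 nM in this assay, and the value of compound 1 lies within the usual scatter of it, so the two compounds are not separated on this read-out. Within the data shown here, no step between measured compounds that differ in one place exists, so nothing yet shows how a single substituent on the core of compound 2 moves the number.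

The next compound, compound 3, `C/[N+]([O-])=C1\CCc2cc(F)ccc21`, keeps that core and differs from compound 2 by fluoro in place of hydrogen on an aromatic carbon. Among the measured compounds shown here, with no comparable step to lean on, the expectation for this assay is a step of modest size, if any, most plausibly toward a lower number, and one that may well stay within the scatter. The step of a 1.3-fold lower number from compound 2 to compound 3 (0.11 log units; within the scatter) is therefore an estimate rather than an inference from the series. Compound 3 is expected to give about 1000 nM in this assay, within a range from 400 nM to 3000 nM.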

Compound 3, half-maximal effective concentration: 1800 nM
The estimate for compound 3 lay 1.8-fold (0.26 log units) below the measured number; low and high end bracket the measured number.
By their numbers in this assay, from the lowest: compounds 2, 1 and 3 (each within the scatter of the next).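

Within the data shown here, this is the first single-place step. In this assay, fluoro in place of hydrogen on an aromatic carbon, meta to a fused ring and para to a fused ring, gives a 1.4-fold higher number from compound 2 to compound 3 (0.14 log units; within the scatter) and so does not separate the two compounds on this read-out. At this position of the six-membered aromatic ring, then, fluoro is compatible with a number in the same range as hydrogen, although this single step gives no direction for further changes. No measurement on hand bears on the reason for this result.

Still open, from the compounds shown here alone, is whether a different group at the same aromatic carbon, such as methoxy, an amine or a carboxylic acid, would produce a step beyond the scatter in this assay. Also open, going by these compounds, are whether fluoro gives a similar result on the other aromatic carbons of the shared core, and whether a longer chain on the ring nitrogen would move the number.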